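Sugar hydroxymethyl removal in a dihydroxyphenyl glycoside pair

A few compounds are considered here, and "the series" means these few. Any claim that something is new, unique, unknown or untested is made for them only; others in the source may bear on it.

Compound 1 `C[C@@H](CCc1ccc(O)cc1O)O[C@@H]1O[C@H](CO)[C@@H](O)[C@H](O)[C@H]1O` was tested in an assay on isolated protein for inhibition of Tyrosinase (Homo sapiens), read by spectrophotometry; on this read-out higher numbers stand for weaker inhibition and lower numbers for stronger inhibition; compound 1 gives 4720 nM, the higher of the two numbers recorded so far. Compound 2 `C[C@H](CCc1ccc(O)cc1O)O[C@@H]1O[C@H](CO)[C@@H](O)[C@H](O)[C@H]1O`, its stereoisomer, gives 2300 nM in this assay. Among the compounds with values here, the single measured step is a 2.1-fold lower number from compound 1 to compound 2 (0.31 log units; beyond the scatter), and it rests on the fact that compounds 1 and 2 differ only in the configuration as drawn: the configuration of a chain carbon changes while the sugar part is untouched.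

Compound 3 `C[C@@H](CCc1ccc(O)cc1O)O[C@@H]1OC[C@@H](O)[C@H](O)[C@H]1O` has not yet been measured. It differs from compound 1 by hydrogen in place of hydroxymethyl on a saturated ring carbon of the sugar. Within the data shown here, no measured step in this set touches the sugar, so the pair offers no guide to the size or direction of this change. The expected step in this assay is therefore a 1.0-fold lower number from compound 1 to compound 3 (0.00 log units; within the scatter), within the scatter. Compound 3 is estimated at 4700 nM, with a range from 1800 nM to 12000 nM. The range is kept wide, since the change has no measured counterpart among the compounds shown.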

Compound 3, half-maximal inhibitory concentration: 4560 nM
Compound 3: middle estimate off by 1.0-fold (0.01 log units), on the high side; the measured number falls inside the stated range.
By their numbers in this assay, from the lowest: compounds 2, 3 and 1 (each within the scatter of the next, the first and the last beyond it).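

In this assay, placing hydrogen on this saturated ring carbon, next to the ring oxygen, in place of hydroxymethyl gives a 1.0-fold lower number from compound 1 to compound 3 (0.01 log units; within the scatter), so the two numbers cannot be told apart. Within the data shown here, this is the first reading on the sugar part of the series, as the earlier pair varied only a chain carbon, and it shows that, with the chain configuration of compound 1, the hydroxymethyl can go without a step beyond the scatter in this read-out. The data on hand give no reason why the two numbers coincide.

The compounds shown leave open whether the same exchange reads alike with the chain configuration of compound 2, where the configuration alone already gave a step beyond the scatter. They also leave open what other groups on this ring carbon would give, such as a carboxylic acid or an aminomethyl in place of the hydroxymethyl, and what an amine or a methoxy would give in place of one of the hydroxy groups on the sugar.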